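A few compounds are considered here, and "the series" means these few. Any claim that something is new, unique, unknown or untested is made for them only; others in the source may bear on it.

The measured compounds:
compound 1, `CCS(=O)(=O)CCC12CCC(c3nnc(-c4ccccc4C)n3C)(CC1)CC2`, 30%
compound 2, `Cn1c(-c2ccccc2C(F)(F)F)nnc1C12CCC(CNS(C)(=O)=O)(CC1)CC2`, 27%

In a functional assay on the whole organism (strain ICR) for inhibition, with Mus musculus as the target, with a stated time of 16 h, at a dose of 10 mg/kg by the oral route (on this read-out lower numbers stand for less inhibition and higher numbers for more inhibition at the one dose given (going by the name of the read-out)), compound 1 gives 30%, and compound 2 gives 27%. Compound 1 holds the higher of the two numbers, but the gap to compound 2 is within the usual scatter, so the two cannot be told apart on these data. For the measured compounds named here, the two structures differ in more than one place, so no single step links them. Compound 3, `CCS(=O)(=O)CCC12CCC(c3nnc(-c4ccccc4Br)n3C)(CC1)CC2`, is related to compound 1 by one change: bromo in place of methyl on an aromatic carbon. Going by the values given here, no measured pair shows what such a change does in this assay, so there is no basis for expecting a step beyond the scatter in either direction. Compound 3 is therefore estimated to give 30% in this assay, with a range from 15% to 45%. The estimated step is no change at the digits printed from compound 1 to compound 3 (within the scatter), expected to be no change beyond the scatter.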

Compound 3, a percentage reported as inhibition, in the whole organism at one dose (the size of the read-out at that dose, not a potency): 65%
Compound 3: the middle estimate sits 35 percentage points below what was measured; the whole stated range lies below it.
By their numbers in this assay, from the lowest: compounds 2 and 1 (each within the scatter of the next); then compound 3.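

Bromo in place of methyl on an aromatic carbon, ortho to a large group, gives a number 35 percentage points higher from compound 1 to compound 3 (beyond the scatter) in this assay at the one dose tested. This position is therefore not indifferent to what it carries, even though the change swaps one heavy atom for one heavy atom and leaves the counts of hydrogen-bond donors and acceptors as they were. Compound 1 and compound 2 differ in more than one place and could show nothing of this kind, and nothing given here accounts for the size of the step.

The compounds shown leave open whether chloro, methoxy or a nitrile at this place on the core of compound 1 would go the same way as bromo. They also leave open whether bromo would give a similar step with the methanesulfonamide side chain of compound 2.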